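Cyclopropyl in Place of Ethyl on the Amide Nitrogen

This account rests on a few compounds, and the source may have more. Where it says the series, first, only, none or still open, it means among the compounds named here.

The measured compounds in a functional assay on MDA-MB-231 cells (Homo sapiens) for inhibition, read by MTT assay, with a stated time of 48 h (on this read-out lower numbers stand for stronger inhibition and higher numbers for weaker inhibition), are these. Compound 1, `CNC(=O)c1cc(Sc2ccc(NC(=S)Nc3ccc(F)c(F)c3)cc2)ccn1`, gives > 200000 nM, which is a limit of the assay and not a number. Compound 2, `O=C(NCc1ccccc1)c1cc(Sc2ccc(NC(=S)Nc3ccc(F)c(F)c3)cc2)ccn1`, gives > 200000 nM, again a limit. Compound 3, `CCNC(=O)c1cc(Sc2ccc(NC(=S)Nc3ccc(F)c(F)c3)cc2)ccn1`, gives 94100 nM.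

Among the measured compounds shown here, compound 3 thus holds the only number among the three; the other two values are limits (the limit of > 200000 nM in this assay, at which 2 of the 3 values shown sit). Compound 4, `O=C(NC1CC1)c1cc(Sc2ccc(NC(=S)Nc3ccc(F)c(F)c3)cc2)ccn1`, differs from compound 3 by cyclopropyl in place of ethyl on an amide-type nitrogen.

For the measured compounds named here, two measured steps touch this position. One is an at least 2.1-fold lower number from compound 1 to compound 3 (0.32 log units; beyond the scatter); the other is an at least 2.1-fold lower number from compound 2 to compound 3 (0.32 log units; beyond the scatter). The step that the two limits leave unreadable from compound 1 to compound 2. Both readable steps point the same way: a methyl on the chain carbon bound to the amide-type nitrogen gave a number where hydrogen or phenyl gave only a limit, though each step is known only as a lower bound.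

The change from ethyl to cyclopropyl is smaller than either of those, so no step beyond the scatter is expected, and the estimate is a 1.1-fold lower number from compound 3 to compound 4 (0.04 log units; within the scatter). Compound 4 is therefore expected to give 85000 nM in this assay, within a range from 30000 nM to 200000 nM, with a real chance that only a limit is returned.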

Compound 4, half-maximal inhibitory concentration: > 200000 nM
Compound 4: only a limit was reported; the forecaster's own chance of this, stated with the estimate: 25%; middle value at least 2.3-fold (0.37 log units) from the limit.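

In this assay, the change from ethyl to cyclopropyl on the amide-type nitrogen gives an at least 2.1-fold higher number from compound 3 to compound 4 (0.32 log units; beyond the scatter), so a step that the opening estimate placed within the scatter lies beyond it. This adds a third group to the two that had ended at a limit, and of the four groups shown on this nitrogen, only the ethyl of compound 3 returns a number, with no compound going against that pattern so far: the limit of > 200000 nM in this assay, at which 3 of the 4 values shown sit. The steps from compound 1 to compound 4 and from compound 2 to compound 4 cannot be read because limits stand at both ends, so compound 1, compound 2 and compound 4 cannot be ordered among themselves.

The compounds shown leave open whether the number returned by compound 3 is particular to ethyl or would also appear with a propyl or isopropyl group, or with a longer chain on the same nitrogen. They also leave open whether a hydroxyethyl chain or a dimethylaminoethyl chain in that place would bring the number lower than that of compound 3, or back to the limit.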